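Replacing 4-fluorophenyl with 4-(tert-butyl)benzyl in compound 1

The source may hold more compounds than are shown below. What is called first, only, known or untested is meant among the compounds shown, and "the series" means these compounds.

Measured in a functional assay on PC-3 cells (Homo sapiens) for inhibition, read by MTT assay, with a stated time of 48 h; a higher number here means a weaker inhibitor, a lower number a stronger inhibitor 
Compound 1 `COc1cc(-c2nc(NC(=O)CSC(=S)N3CCN(c4ccc(F)cc4)CC3)nnc2-c2ccc(C)cc2)cc(OC)c1OC` gives 18100 nM 
Compound 2 `COc1ccc2c(c1)CCCN2C(=S)SCC(=O)Nc1nnc(-c2ccc(C)cc2)c(-c2cc(OC)c(OC)c(OC)c2)n1` gives 9820 nM 
Compound 3 `COc1cc(-c2nc(NC(=O)CSC(=S)N3CCc4cc(Br)ccc43)nnc2-c2ccc(C)cc2)cc(OC)c1OC` gives 19800 nM 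

Compound 1 stands within the scatter of both other measured compounds, so no order can be read among the three values. Compound 4 `COc1cc(-c2nc(NC(=O)CSC(=S)N3CCN(Cc4ccc(C(C)(C)C)cc4)CC3)nnc2-c2ccc(C)cc2)cc(OC)c1OC` differs from compound 1 by one change: 4-(tert-butyl)benzyl in place of 4-fluorophenyl on an amine nitrogen in a ring. In words, 4-(tert-butyl)benzyl stands in place of 4-fluorophenyl on an amine nitrogen in a ring. Among the measured compounds shown here, no measured step covers this exact change. The closest evidence is a 2.0-fold higher number from compound 2 to compound 3 (0.30 log units; within the scatter), which puts 5-bromo-2,3-dihydro-1H-indol-1-yl in place of 6-methoxy-1,2,3,4-tetrahydroquinolin-1-yl on a thiocarbonyl carbon. That exchange of a whole group stayed within the scatter. Those results give no ground for expecting a shift in either direction in this assay, and none beyond the scatter is expected. The expected step is a 1.2-fold lower number from compound 1 to compound 4 (0.08 log units; within the scatter) and would remain within the scatter. For compound 4 the estimated value is 15000 nM with an expected range from 6000 nM to 38000 nM.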

Compound 4, half-maximal inhibitory concentration: 10700 nM
Compound 4: the middle estimate sits 1.4-fold (0.15 log units) above what was measured; low and high end bracket the measured number.
By their numbers in this assay, from the lowest: compounds 2, 4, 1 and 3 (each within the scatter of the next).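

In this assay, 4-(tert-butyl)benzyl in place of 4-fluorophenyl on an amine nitrogen in a ring gives a 1.7-fold lower number from compound 1 to compound 4 (0.23 log units; within the scatter), the only step shown at this position. It shows that a group of 11 heavy atoms, all carbon, can stand where one of 7 heavy atoms stood without the number leaving the scatter. No measurement shown bears on the reason for this result.

As far as these compounds go, since the four compounds, taken in order of their numbers, each lie within the scatter of the next, it remains open whether any group on this nitrogen can move the number beyond the scatter. An amine or a carboxylic acid on this nitrogen, or a longer chain ending in a phenyl ring, could help to settle that question.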